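Methoxy in Place of Chloro: What Compound 4 Might Show

This account rests on a few compounds, and the source may have more. Where it says the series, first, only, none or still open, it means among the compounds named here.

Of the compounds shown here, three sharing one core have been tested in a functional assay on MOLT-4 cells (Homo sapiens) for cytotoxicity, with a stated time of 72 h; on this read-out higher numbers stand for weaker inhibition and lower numbers for stronger inhibition. Compound 1 `O=C1/C(=C/c2ccccc2)CCC/C1=C\c1cccc([N+](=O)[O-])c1`, the unsubstituted parent, gives 1700 nM. Compound 2 `Cc1ccc(/C=C2\CCC/C(=C\c3cccc([N+](=O)[O-])c3)C2=O)cc1` carries a methyl on an aromatic carbon of the same ring and gives 9530 nM, so that a 5.6-fold higher number from compound 1 to compound 2 (0.75 log units; beyond the scatter). Compound 3 `O=C1/C(=C/c2ccc(Cl)cc2)CCC/C1=C\c1cccc([N+](=O)[O-])c1` carries a chloro at that place and gives 2020 nM; here a 1.2-fold higher number from compound 1 to compound 3 (0.07 log units; within the scatter), while a 4.7-fold lower number from compound 2 to compound 3 (0.67 log units; beyond the scatter). Compound 3 thus stands second highest of the three numbers, close to compound 1 and well apart from compound 2.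

Compound 4 `COc1ccc(/C=C2\CCC/C(=C\c3cccc([N+](=O)[O-])c3)C2=O)cc1` has not yet been measured. It differs from compound 3 by methoxy in place of chloro on an aromatic carbon. Going by the values given here, two measured steps bear on this position: the methyl brought a modest loss of potency, whereas the chloro left the number within the scatter of the parent. Methoxy is neither of these groups, so the direction is uncertain; a modest rise in the number, or none beyond the scatter, is the expectation.

Compound 4 is therefore estimated at 4000 nM, with a range from 1500 nM to 11000 nM. The expected step is a 2.0-fold higher number from compound 3 to compound 4 (0.30 log units; within the scatter).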

Compound 4, half-maximal inhibitory concentration: 7980 nM
Beside the measured number, compound 4's estimate is 2.0-fold (0.30 log units) below it; measured number inside the range.
By their numbers in this assay, from the lowest: compounds 1 and 3 (each within the scatter of the next); then compounds 4 and 2 (each within the scatter of the next).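

In this assay, methoxy at this place falls with methyl rather than with chloro: the number rises from the unsubstituted parent (a 4.7-fold higher number from compound 1 to compound 4 (0.67 log units; beyond the scatter)) and from the chloro compound (a 4.0-fold higher number from compound 3 to compound 4 (0.60 log units; beyond the scatter)), yet it stays level with the methyl compound (a 1.2-fold lower number from compound 2 to compound 4 (0.08 log units; within the scatter)). Going by these compounds alone, the earlier compounds showed only that one group moved the number and another did not, so they could not say which was the exception; with compound 4, chloro is the only one of the three groups that stays within the scatter of the parent, while methyl and methoxy both go against it. Nothing measured here accounts for why chloro parts from the other two groups at this place.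

The compounds shown carry only hydrogen, methyl, chloro and methoxy at this place, so it remains open whether a fluoro, an amine or a carboxylic acid there would side with compounds 1 and 3 or with compounds 2 and 4. As far as these compounds go, it also remains open whether methoxy elsewhere on the same ring would give a similar step.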